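This account rests on a few compounds, and the source may have more. Where it says the series, first, only, none or still open, it means among the compounds named here.

Measured in a physicochemical assay for lipophilicity, read by HPLC, at pH 7.4; on this read-out lower numbers stand for lower lipophilicity and higher numbers for higher lipophilicity:
- compound 1 `C[C@@H](Oc1cc2oc(=O)n(CCC(=O)O)c2cc1Cl)c1ccc(F)cn1`: 1.98
- compound 2 `O=C(O)CCn1c(=O)oc2cc(OCc3ccccn3)c(Cl)cc21`: 1.32
- compound 3 `O=C(O)CCn1c(=O)oc2cc(OCC3CC3)c(Cl)cc21`: 2.09

In this assay compound 3 gives 2.09, within the scatter of compound 1. Only compound 2 stands clearly lower. The next structure, compound 4 `C[C@@H](Oc1cc2oc(=O)n(CCC(=O)O)c2cc1Cl)c1ncccn1`, is reached by a group of 8 heavy atoms (6 carbon, 2 nitrogen; one six-membered aromatic ring with 2 hetero atoms) in place of a group of 4 heavy atoms (4 carbon; one three-membered non-aromatic ring of carbon only), on an oxygen on an aromatic ring. The entering group carries one six-membered aromatic ring with 2 hetero atoms.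

Among the compounds with values here, the one measured step that bears on this is a number 0.77 log units higher from compound 2 to compound 3 (beyond the scatter), with cyclopropyl in place of pyridin-2-yl. Read backwards, it suggests a drop beyond the scatter when an aromatic ring with hetero atoms replaces the cyclopropyl ring. Compound 1 goes against this reading, since it also carries such a ring yet gives 1.98. Its group differs from that of compound 4, so compound 2 is weighted more heavily here. A downward step of similar or somewhat larger size is expected. The expected change is a number 0.99 log units lower from compound 3 to compound 4 (beyond the scatter). For compound 4 the estimate is 1.1, with an expected range of 0.7 to 1.5.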

Compound 4, distribution coefficient: 0.83
Beside the measured number, compound 4's estimate is 0.27 log units above it, and the stated range covers the measured number.
By their numbers in this assay, from the lowest: compound 4; then compound 2; then compounds 1 and 3 (each within the scatter of the next).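

In this assay, within the data shown here, the group on the oxygen on the aromatic ring spans a wider range than the earlier compounds showed (a number 1.26 log units lower from compound 3 to compound 4 (beyond the scatter)), and compound 4 now has the lowest number of the four. Pyrimidin-2-yl in place of 5-fluoropyridin-2-yl gives the clearest reading (a number 1.15 log units lower from compound 1 to compound 4 (beyond the scatter)): an aromatic ring with hetero atoms does not by itself bring a low number, as compound 1 shows, and the identity of that ring matters. The second hetero atom of the ring also counts against the pyridin-2-yl group of compound 2 (a number 0.49 log units lower from compound 2 to compound 4 (beyond the scatter)), although that comparison also includes the added methyl on the chain carbon.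

Going by these compounds, the contribution of that methyl alone remains open, as does the reading for a plain phenyl ring or a longer chain in this place. No measurement here accounts for the size of these steps.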